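This account rests on a few compounds, and the source may have more. Where it says the series, first, only, none or still open, it means among the compounds named here.

Three compounds of one series were tested in a functional assay on the whole organism (strain Wistar albino) for inhibition, with Rattus norvegicus as the target, read by paw edema, with stated times of 1 h and 2 h, at a dose of 0.32 mmol/kg by the intraperitoneal route; a higher number here means more inhibition at the dose given (going by the name of the read-out), a lower number less inhibition. Compound 1, `COc1ccc(-c2nn(-c3ccc(Cl)cc3)cc2C(CC(=O)c2ccc(Cl)cc2)C(=O)c2ccc(F)cc2)cc1`, gives 19.8% in this assay. Compound 2, `COc1ccc(C(=O)C(CC(=O)c2ccc(Cl)cc2)c2cn(-c3ccc(Cl)cc3)nc2-c2ccc(OC)cc2)cc1`, gives 0% in this assay; the difference between them is methoxy in place of fluoro on an aromatic carbon, and the step of a number 19.8 percentage points lower from compound 1 to compound 2 (beyond the scatter). Compound 3, `Cc1ccc(-c2nn(-c3ccc(S(N)(=O)=O)cc3)cc2C(CC(=O)c2ccc(Cl)cc2)C(=O)c2ccc(F)cc2)cc1`, gives 53.5% in this assay, the highest of the three numbers, beyond the scatter from both compound 1 and compound 2. How the core of compound 3 differs from the core of compound 1 is not broken down here.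

Compound 4, `COc1ccc(C(=O)C(CC(=O)c2ccc(Cl)cc2)c2cn(-c3ccc(S(N)(=O)=O)cc3)nc2-c2ccc(C)cc2)cc1`, has not yet been measured. It differs from compound 3 by methoxy in place of fluoro on an aromatic carbon, the same change that separates compound 1 from compound 2, at a place described in the same words. Going by the values given here, because of a number 19.8 percentage points lower from compound 1 to compound 2 (beyond the scatter), a lowering of similar, modest size is expected from compound 3 to compound 4, although only one earlier instance of the change is available, so the expectation is uncertain. The expected step for compound 4 is a number 19.5 percentage points lower from compound 3 to compound 4 (beyond the scatter), and compound 4 is estimated to give 34% in this assay, within 15% to 50%.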

Compound 4, a percentage reported as inhibition, in the whole organism at one dose (the size of the read-out at that dose, not a potency): 53.8%
Beside the measured number, compound 4's estimate is 19.8 percentage points below it, and the stated range ends below it.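

In this assay, methoxy in place of fluoro on the aromatic carbon gives a number 0.3 percentage points higher from compound 3 to compound 4 (within the scatter), so the lowering seen on the core of compound 1 does not appear on the core of compound 3. The effect of this change therefore cannot be carried as a fixed amount from one of these cores to the other: the same change on two cores in this assay, a number 19.8 percentage points lower (beyond the scatter) from compound 1 to compound 2 and a number 0.3 percentage points higher (within the scatter) from compound 3 to compound 4, 20.1 percentage points apart, beyond the scatter of two such steps

Going by these compounds alone, with only one pair on each core, this does not show which part of the two cores decides the outcome, nor how the change would behave on any further core.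

The compounds shown leave open how other groups would read at the same aromatic carbon, for example an amine, a carboxylic acid or the longer ethoxy chain. They also leave open whether the result on the core of compound 3 would hold for such groups or is particular to the exchange of fluoro for methoxy.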